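The compounds below may be only part of what the source reports. "The series", "measured", "known", "first", "only" and "open" are said of these compounds alone.

Compound 1, with the structure `COc1ccc(/C=N\NC(=S)NC(C)(C)CCC[C@](C)(O)[C@@H]2CC=C(C)CC2)cc1`, is the starting point. In a functional assay on K562 cells (Homo sapiens) for cytotoxicity, read by sulforhodamine B assay (a higher number here means that more compound is tolerated, a lower number that less compound is tolerated), compound 1 reaches only the limit of the assay, > 100000 nM, so no number is known for it, and it stands at the limit of > 100000 nM in this assay, at which 1 of the 2 values shown sits. Among the measured compounds shown here, its partner compound 2, with the structure `CC1=CC[C@@H]([C@@](C)(O)CCCC(C)(C)NC(=S)N/N=C\c2ccc([N+](=O)[O-])cc2)CC1`, is the one compound here with a measured number: in this assay compound 2 gives 45500 nM. The step from compound 1 to compound 2, nitro in place of methoxy on an aromatic carbon, comes out as an at least 2.1-fold lower number from compound 1 to compound 2 (0.34 log units; beyond the scatter).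

Compound 3, with the structure `CC1=CC[C@@H]([C@@](C)(O)CCCC(C)(C)NC(=S)N/N=C(/C)c2ccccc2)CC1`, is not yet measured. It differs from compound 1 by a group of 9 heavy atoms (8 carbon, 1 nitrogen; one six-membered aromatic ring of carbon only) in place of a group of 10 heavy atoms (8 carbon, 1 nitrogen, 1 oxygen; one six-membered aromatic ring of carbon only), on an amide-type nitrogen. For the measured compounds named here, the one measured step touches a different part of that group, so it offers no direct guide; it only shows that a change there can move the number somewhat. With compound 1 at the limit, the estimate for compound 3 is 90000 nM, between 35000 nM and 250000 nM, meaning an expected step of an at least 1.1-fold lower number from compound 1 to compound 3 (0.04 log units; that floor lies within the scatter) that may stay within the scatter or end at the limit again.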

Compound 3, concentration lethal to 50% of the cells: 1540 nM
Estimate against measurement, compound 3: 58-fold (1.77 log units) above; the measured number lies below the stated range.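

Among the compounds shown here, the single earlier step gave little sign of how much this position could matter, but the group on the amide-type nitrogen turns out to move the number strongly. In this assay, the new group gives an at least 64-fold lower number from compound 1 to compound 3 (1.81 log units; beyond the scatter), a large step, whereas nitro in place of methoxy gave an at least 2.1-fold lower number from compound 1 to compound 2 (0.34 log units; beyond the scatter). Both the leaving and the entering group hold one six-membered aromatic ring of carbon only and 1 double bond outside aromatic rings, so this large step comes without a change in those counts, while the entering group has no oxygen and 1 hydrogen-bond acceptor where the leaving group has 2; the step is only a floor, and compound 1 stands at a limit, not at a number: the limit of > 100000 nM in this assay, at which 1 of the 3 values shown sits.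

The two groups differ in more than one feature, so the compounds shown cannot tell which part of the change goes with the lower number in compound 3. They also leave open whether a group carrying an amine or a carboxylic acid on that nitrogen, or a longer chain in place of the aromatic ring, would keep the number this low.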